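A few compounds are considered here, and "the series" means these few. Any claim that something is new, unique, unknown or untested is made for them only; others in the source may bear on it.

Measured so far in a functional assay on HCT-116 cells (Homo sapiens) for antiproliferative activity, read by MTT assay, with a stated time of 72 h; a higher number here means a weaker inhibitor, a lower number a stronger inhibitor:

Compound 1 `O=C1COc2ccc(-c3cnc4ccccc4c3)cc2N1C1CCCCC1` returns only a limit of the assay, > 40000 nM.
Compound 2 `COc1ccc(N2C(=O)COc3ccc(-c4cnc5ccccc5c4)cc32)cc1` likewise returns only a limit of the assay, > 40000 nM.
Compound 3 `COc1ccc(N2C(=O)COc3ccc(-c4cccc(NS(=O)(=O)c5ccc(F)cc5)c4)cc32)cc1` returns a number, 28300 nM.

Compound 3 thus carries the only numerical read-out in this assay; the other two values sit at the limit of > 40000 nM in this assay, at which 2 of the 3 values shown sit. The difference between the core of compound 3 and the core of compound 2 is not broken down here.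

Within the pair compound 2 and compound 1, the single change is cyclohexyl in place of 4-methoxyphenyl on an amide-type nitrogen in a ring. The step that the two limits leave unreadable from compound 2 to compound 1 cannot be read, since both ends are limits.

Compound 4 `O=C1COc2ccc(-c3cccc(NS(=O)(=O)c4ccc(F)cc4)c3)cc2N1C1CCCCC1` is not yet measured. It arises from compound 3 by cyclohexyl in place of 4-methoxyphenyl on an amide-type nitrogen in a ring, the same change as from compound 2 to compound 1; the place lines of the two changes agree word for word, so this is the same change on the shared core of the amide-type nitrogen in a ring.

The step from compound 2 to compound 1 gives no readable size, so the expectation for compound 4 rests only on compound 3 at 28300 nM and on the flat picture of the series in this assay. An expected step of a 1.2-fold higher number from compound 3 to compound 4 (0.09 log units; within the scatter) of roughly zero is taken, with wide error. Compound 4 is therefore estimated at 35000 nM, between 12000 nM and 90000 nM, with a real chance that this assay reports only a limit for it.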

Compound 4, half-maximal inhibitory concentration: 18300 nM
For compound 4 the middle estimate is 1.9-fold (0.28 log units) above the measured one; low and high end bracket the measured number.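

In this assay, cyclohexyl in place of 4-methoxyphenyl on an amide-type nitrogen in a ring gives a 1.5-fold lower number from compound 3 to compound 4 (0.19 log units; within the scatter), so on the core of compound 3 this exchange of a six-membered aromatic ring for a non-aromatic one leaves no difference that can be told from repeat measurements. This is a single readable pair on a single core: it shows that the change is without a readable effect there, and it cannot establish a rule for the series. Whether the change behaves alike on another core stays unread, as the same change from compound 2 to compound 1 joins two limits and gives no size to set against the new step: the limit of > 40000 nM in this assay, at which 2 of the 4 values shown sit.

The compounds shown leave open whether any other group on the amide-type nitrogen in a ring, such as a longer chain or a chain ending in an amine or a carboxylic acid, would give a step beyond the scatter. Also open, from the compounds shown here alone, is whether cyclohexyl and 4-methoxyphenyl would still read alike on a core with a number well away from the limit of the assay.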